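A few compounds are considered here, and "the series" means these few. Any claim that something is new, unique, unknown or untested is made for them only; others in the source may bear on it.

The shared core is seen most plainly in compound 2 `Cc1ccc(OCC(=O)N(C)Cc2cccs2)cc1`, where a methyl sits on the amide-type nitrogen; in an assay on HEK293 cells for agonist activity at transient receptor potential cation channel subfamily M member 8 (Homo sapiens), read by fluorescence and calcium flux, with a stated time of 15 min (a higher number here means that more compound is needed for the effect, a lower number that less compound is needed), compound 2 gives 400 nM. Compound 1 `Cc1ccc(OCC(=O)N(Cc2cccs2)c2cnn(C)c2)cc1` carries a 1-methyl-1H-pyrazol-4-yl on that nitrogen, and in this assay compound 1 gives 63000 nM. Compound 3 `Cc1ccc(OCC(=O)N(Cc2cccs2)c2ccncc2)cc1` carries a pyridin-4-yl there, and in this assay compound 3 gives 52 nM, the lowest of the three numbers. Its standing follows from the steps: a 1200-fold lower number from compound 1 to compound 3 (3.08 log units; beyond the scatter) and a 7.7-fold lower number from compound 2 to compound 3 (0.89 log units; beyond the scatter), while between the other two a 160-fold lower number from compound 1 to compound 2 (2.20 log units; beyond the scatter).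

Among the measured compounds shown here, compound 4 `Cc1ccc(OCC(=O)N(Cc2cccs2)c2ccon2)cc1` has not yet been measured. 1,2-oxazol-3-yl in place of pyridin-4-yl on an amide-type nitrogen The step that bears most on this change is the one from compound 1 to compound 3, where a five-membered aromatic ring with two hetero atoms was exchanged for a six-membered ring with one hetero atom, and a 1200-fold lower number from compound 1 to compound 3 (3.08 log units; beyond the scatter) was the result. The change to compound 4 runs the other way in ring size and hetero atom count, so a higher number is expected, though the two five-membered rings are not the same and the size is uncertain. Compound 4 is therefore expected to give 1500 nM in this assay, within a range of 200 nM to 15000 nM. This expected outcome corresponds to a 29-fold higher number from compound 3 to compound 4 (1.46 log units; beyond the scatter).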

Compound 4, half-maximal effective concentration: 2 nM
For compound 4 the middle estimate is 750-fold (2.88 log units) above the measured one, and the stated range ends above it.
By their numbers in this assay, from the lowest: compound 4; then compound 3; then compound 2; then compound 1.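

In this assay, a five-membered aromatic ring with two hetero atoms on the amide-type nitrogen does not by itself raise the number, as the opening step from the 1-methyl-1H-pyrazol-4-yl had suggested: the 1,2-oxazol-3-yl gives a 32000-fold lower number from compound 1 to compound 4 (4.50 log units; beyond the scatter) and so places two rings of that description at opposite ends of the series. Nor is a six-membered ring needed for a low number at this place, since 1,2-oxazol-3-yl in place of pyridin-4-yl gives a 26-fold lower number from compound 3 to compound 4 (1.41 log units; beyond the scatter) and compound 4 has the lowest number of the four. Measured against the methyl, the new ring gives a 200-fold lower number from compound 2 to compound 4 (2.30 log units; beyond the scatter) in a series where compound 1 stands above compound 2, so an aromatic ring on this nitrogen can move the number far in either direction, depending on which ring it is.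

As far as these compounds go, whether a plain phenyl, or a 1H-pyrazol-4-yl without its methyl, would fall near compound 4 or near compound 1 stays open in these compounds. Nothing measured here speaks to what lies behind the size of this step.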